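Series notes: acyclic amide replacing the cyclic sulfonamide

A few compounds are considered here, and "the series" means these few. Any claim that something is new, unique, unknown or untested is made for them only; others in the source may bear on it.

Going by the values given here, compound 1 `CC(C)C(c1ccc(-c2ccc3cccc(F)c3c2)[nH]c1=O)N1CCCCS1(=O)=O` is one of two compounds measured in an ADME assay on microsomes from liver (Rattus norvegicus) for metabolic stability; a higher number here means that the compound lasts longer, a lower number that the compound disappears faster; compound 1 gives 0.07 h. Among the compounds with values here, compound 2 `CC(C)C(c1cnc(N)s1)c1ccc(-c2ccc3cccc(F)c3c2)[nH]c1=O` gives 0.0983 h in this assay, and the single measured step, a 1.4-fold higher number from compound 1 to compound 2 (0.15 log units; within the scatter), lies within the scatter, so the two cannot be separated on these numbers. Within the data shown here, compound 3 `CC(C)NC(=O)CC(c1ccc(-c2ccc3cccc(F)c3c2)[nH]c1=O)C(C)C` differs from compound 1 as follows: a group of 7 heavy atoms (5 carbon, 1 nitrogen, 1 oxygen; no ring) in place of a group of 8 heavy atoms (4 carbon, 1 nitrogen, 2 oxygen, 1 sulfur; one six-membered non-aromatic ring with 2 hetero atoms), on a saturated chain carbon bound to an aromatic carbon and a saturated chain carbon The measured step exchanges a different group and does not bear on this change; no other step is available. Compound 3 is therefore expected to give 0.1 h in this assay, within 0.03 h to 0.35 h, an expected step of a 1.4-fold higher number from compound 1 to compound 3 (0.15 log units; within the scatter).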

Compound 3, half-life: < 0.0667 h
Compound 3 ended at the assay's limit (the forecaster's own chance of this, stated with the estimate: 5%); middle value at least 1.4-fold (0.17 log units) from the limit.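

In this assay compound 3 gives < 0.0667 h, which is a limit of the assay and not a number. Placing (isopropylcarbamoyl)methyl on this saturated chain carbon gives an at least 1.0-fold lower number from compound 1 to compound 3 (0.02 log units; that floor lies within the scatter) and an at least 1.4-fold lower number from compound 2 to compound 3 (0.16 log units; that floor lies within the scatter), and since both floors lie within the scatter, neither step separates the open-chain amide from the group it replaces. Three different groups at this position, with and without a ring, therefore remain unseparated on these numbers.

On these data alone, the true size of both steps stays open, since compound 3 has only a limit. As far as these compounds go, whether an amine or a carboxylic acid on this carbon would move the half-life beyond the scatter also stays open.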